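Adding a Dimethylamino Group to a Potent Substance-P Antagonist

The source may report more compounds than this note shows. Statements on the series, on what has been measured and on what is new or still open speak of the compounds shown alone.

Of the compounds shown here, two of a shared core have been measured in a functional assay on ileum for antagonist activity at Substance-P receptor (Cavia porcellus); on this read-out higher numbers stand for weaker inhibition and lower numbers for stronger inhibition. Compound 1 `Cc1ccccc1-c1nc(N(C)C)nc2c1C(=O)N(Cc1cc(C(F)(F)F)cc(C(F)(F)F)c1)C[C@@H](C)CO2` gives 52.9 nM. Compound 2 `Cc1ccccc1-c1ncnc2c1C(=O)N(Cc1cc(C(F)(F)F)cc(C(F)(F)F)c1)C[C@H](C)CO2` gives 12.6 nM, the lowest of the two numbers; the gap to compound 1 lies beyond the scatter. Compound 3 `Cc1ccccc1-c1nc(N(C)C)nc2c1C(=O)N(Cc1cc(C(F)(F)F)cc(C(F)(F)F)c1)C[C@H](C)CO2` differs from compound 2 in one place: dimethylamino in place of hydrogen on an aromatic carbon. For the measured compounds named here, no measured pair shows this change directly. The step from compound 2 to compound 3 is expected to be a modest rise in the number, about a 2.4-fold higher number from compound 2 to compound 3 (0.38 log units; beyond the scatter), near the edge of the scatter. Compound 3 is therefore estimated at 30 nM, with a range from 8 nM to 110 nM.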

Compound 3, antagonist equilibrium constant: 0.427 nM
Beside the measured number, compound 3's estimate is 70-fold (1.85 log units) above it; the measured number lies below the stated range.
By their numbers in this assay, from the lowest: compound 3; then compound 2; then compound 1.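

In this assay, placing dimethylamino on the aromatic carbon between two ring nitrogen atoms gives a 30-fold lower number from compound 2 to compound 3 (1.47 log units; beyond the scatter), so this position not only accepts the group but gains greatly from it when the stereocentre is drawn S. With the same group in place, the configuration alone also matters greatly, giving a 120-fold lower number from compound 1 to compound 3 (2.09 log units; beyond the scatter). That step can be read as purely stereochemical because of one fact: the fact that compounds 1 and 3 differ only in the configuration as drawn.

Going by these compounds, whether methylamino or a morpholine ring would match dimethylamino at this position stays open. So does the size of the stereocentre's effect when this position carries only hydrogen.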